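The source may hold more compounds than are shown below. What is called first, only, known or untested is meant among the compounds shown, and "the series" means these compounds.

Within the data shown here, compound 1 `Cn1c(-c2ccccc2C(F)(F)F)nnc1C12CCC(CCS(=O)(=O)C(C)(C)C)(CC1)CC2` gives 65% in a functional assay on the whole organism (strain ICR) for inhibition, with Mus musculus as the target, with a stated time of 4 h, at a dose of 10 mg/kg by the oral route (on this read-out lower numbers stand for less inhibition and higher numbers for more inhibition at the one dose given (going by the name of the read-out)), the lower of the two numbers known so far. Compound 2 `CCS(=O)(=O)CCC12CCC(c3nnc(-c4ccccc4Br)n3C)(CC1)CC2` gives 86% in this assay, a gap beyond the usual scatter. Compound 3 `CC(C)S(=O)(=O)CCC12CCC(c3nnc(-c4ccccc4C(F)(F)F)n3C)(CC1)CC2` differs from compound 1 by a single change: hydrogen in place of methyl on a saturated chain carbon bound to two saturated chain carbons and a sulfonyl sulfur. Among the measured compounds shown here, no measured pair shows this change, so the expectation rests on compound 1 alone. Compound 3 is expected to sit close to compound 1, with a step of a number 3 percentage points lower from compound 1 to compound 3 (within the scatter) that stays within the scatter rather than moving clearly in either direction. The estimate for compound 3 is 62%, ranging from 42% to 80%.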

Compound 3, a percentage reported as inhibition, in the whole organism at one dose (the size of the read-out at that dose, not a potency): 88%
For compound 3 the middle estimate is 26 percentage points below the measured one, outside the stated range (above it).
By their numbers in this assay, from the lowest: compound 1; then compounds 2 and 3 (each within the scatter of the next).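

In this assay, among these compounds, going from tert-butyl to isopropyl on the sulfonyl gives a number 23 percentage points higher from compound 1 to compound 3 (beyond the scatter), so this position responds to the loss of a single methyl, which the earlier compounds could not show. Compound 2 carries other changes as well, so it does not isolate this effect. Nothing at hand explains this rise.

From the compounds shown here alone, whether a cyclopropyl or a plain methyl on the sulfonyl would keep this level stays open. So does the outcome of a longer chain there, such as tert-pentyl.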